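Swapping a thiazole amide for a chlorinated benzamide

The source may hold more compounds than are shown below. What is called first, only, known or untested is meant among the compounds shown, and "the series" means these compounds.

Compound 1 has the structure `Cc1nc(C(=O)Nc2ccc(Cl)c(-c3nnc4c(Cl)cccn34)c2)cs1`. In a functional assay on T47D cells (Homo sapiens) for antiproliferative activity, read by MTT assay, with a stated time of 72 h (on this read-out higher numbers stand for weaker inhibition and lower numbers for stronger inhibition), compound 1 gives only a limit of the assay, > 100000 nM. Compound 2, `O=C(Nc1ccc(Cl)c(-c2nnc3c(Cl)cccn23)c1)c1ccccc1`, carries a plain phenyl on the carbonyl carbon in place of the 2-methyl-1,3-thiazol-4-yl group. In this assay compound 2 likewise reaches only a limit, > 100000 nM. Within the data shown here, the single measured step, a step that the two limits leave unreadable from compound 1 to compound 2, therefore cannot be sized; all that is known is the limit of > 100000 nM in this assay, at which 2 of the 2 values shown sit. Compound 3, `O=C(Nc1ccc(Cl)c(-c2nnc3c(Cl)cccn23)c1)c1ccccc1Cl`, is not yet measured. It differs from compound 1 as follows: 2-chlorophenyl in place of 2-methyl-1,3-thiazol-4-yl on a carbonyl carbon. Among the measured compounds shown here, the only step that bears on this change is the one to compound 2, and it shows nothing but two limits, so neither a direction nor a size can be read from it. Compound 3 is therefore expected to give about 200000 nM, within 50000 nM to 1000000 nM, most likely reported again as a limit. The expected step is a step that the limit leaves unreadable from compound 1 to compound 3.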

Compound 3, half-maximal inhibitory concentration: 83800 nM
Compound 3: the middle estimate sits 2.4-fold (0.38 log units) above what was measured; the range from low to high includes it.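

In this assay, among these compounds, compound 3 gives 83800 nM, the first actual number in this set rather than a limit of the assay. Chloro in place of hydrogen on an aromatic carbon amounts to an at least 1.1-fold lower number from compound 2 to compound 3 (0.07 log units; that floor lies within the scatter), and 2-chlorophenyl in place of 2-methyl-1,3-thiazol-4-yl amounts to an at least 1.1-fold lower number from compound 1 to compound 3 (0.07 log units; that floor lies within the scatter); each is only a floor, so the true size of both steps stays unknown. Compound 1 and compound 2 remain limits and not numbers: the limit of > 100000 nM in this assay, at which 2 of the 3 values shown sit.

Still open, on these data alone, is whether the chloro group is special here, or whether a methyl or methoxy group on the same phenyl ring would also give a readable number. Also open, as far as these compounds go, is whether an amine or a carboxylic acid on that ring would give a number at all in this assay.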